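Ortho-halogen swap on the benzylidene ketone series

A few compounds are considered here, and "the series" means these few. Any claim that something is new, unique, unknown or untested is made for them only; others in the source may bear on it.

Measured so far:
- compound 1, `O=C1/C(=C/c2ccc(Cl)cc2Cl)CCCc2ccccc21`: > 500000 nM
- compound 2, `O=C1/C(=C/c2ccccc2F)Cc2ccccc21`: 150000 nM
- compound 3, `Cc1ccccc1/C=C1\CCc2ccccc2C1=O`: 50200 nM

Three compounds share the arylidene ketone core and have been run in a functional assay on L1210 cells (Mus musculus) for inhibition; a lower number here means a stronger inhibitor, a higher number a weaker inhibitor. Compound 1, which carries a seven-membered ring in its core and a dichlorophenyl arm, gives only a limit, > 500000 nM, and no number (the limit of > 500000 nM in this assay, at which 1 of the 3 values shown sits). Of the two numbered values, compound 2 with its ortho-fluoro arm gives 150000 nM and stands highest; compound 3 with the ortho-methyl arm gives 50200 nM, a lower number by a margin beyond the scatter of this assay. Among the measured compounds shown here, no pair among the measured compounds differs in a single place, so no measured step exists within the set.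

The next compound, compound 4, `O=C1/C(=C/c2ccccc2Br)Cc2ccccc21`, has not yet been measured in this assay. It differs from compound 2 by bromo in place of fluoro on an aromatic carbon. For the measured compounds named here, with no measured step to lean on, the expectation is a modest shift at most, with direction uncertain; a change within the scatter would not be surprising, and a small move towards a lower number is slightly favoured. The estimate for compound 4 in this assay is 90000 nM, with a range from 25000 nM to 320000 nM, which is expected to correspond to a step of a 1.7-fold lower number from compound 2 to compound 4 (0.22 log units; within the scatter).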

Compound 4, half-maximal inhibitory concentration: 64200 nM
For compound 4 the middle estimate is 1.4-fold (0.15 log units) above the measured one; measured number inside the range.
By their numbers in this assay, from the lowest: compounds 3 and 4 (each within the scatter of the next); then compound 2. At a limit, above all of these: compound 1.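

In this assay the series now has its first measured single-place step: bromo in place of fluoro on an aromatic carbon of the six-membered aromatic ring, ortho to a large group, gives a 2.3-fold lower number from compound 2 to compound 4 (0.37 log units; beyond the scatter). This shows that the number responds to the identity of the halogen at this position on the shared core, with the heavier halogen giving the stronger inhibitor, although the step is modest and rests on a single pair. Nothing available here bears on why the swap moves the number, so the step stands as an observation without a cause.

As far as these compounds go, two halogens define no trend, so it remains open whether chloro would fall in line with this pair and how a methoxy group, an amine or a carboxylic acid at the same place would read. From the compounds shown here alone, it also remains open whether the same swap would give a similar step on the core of compound 3 or on the core of compound 1, since a step on one core need not carry over to another.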